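Triazole analogs: amino swapped for methoxy on the pendant ring

The compounds below may be only part of what the source reports. "The series", "measured", "known", "first", "only" and "open" are said of these compounds alone.

Of the compounds shown here, two of a shared core have been tested in a functional assay on MDA-MB-231 cells (Homo sapiens) for cytotoxicity, read by MTT assay (on this read-out lower numbers stand for stronger inhibition and higher numbers for weaker inhibition), so far. Compound 1 `COc1ccc(-c2cn(-c3ccc(OC)c(OC)c3)nn2)cc1O` gives a value that is only a limit of the assay, > 100 nM. Compound 2 `COc1ccc(-n2cc(-c3ccc(N)cc3)nn2)cc1OC` likewise gives only a limit, > 10000 nM. Because both results are limits the limit of > 100 nM in this assay, at which 1 of the 2 values shown sits, and (the limit of > 10000 nM in this assay, at which 1 of the 2 values shown sits), no numbered step between them can be drawn, and compound 2 stands at the weaker of the two limits. Compound 3 `COc1ccc(-c2cn(-c3ccc(OC)c(OC)c3)nn2)cc1` is the next candidate; it differs from compound 2 by methoxy in place of amino on an aromatic carbon. Going by the values given here, with no measured step to lean on, the change is expected to move the result little beyond the usual scatter, and compound 3 is expected to stay weak. The step from compound 2 to compound 3 is therefore estimated as a step that the limit leaves unreadable from compound 2 to compound 3. For compound 3 the estimate in this assay is 20000 nM, with a range from 3000 nM to 100000 nM.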

Compound 3, half-maximal inhibitory concentration: > 10000 nM
Compound 3 was reported as a limit (the forecaster's own chance of this, stated with the estimate: 70%); the middle value is on the limit's open side.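

No new step can be read: compound 1, compound 2 and compound 3 all stand as limits, not numbers, and the steps among them cannot be sized. The compounds shown leave open whether methoxy in place of amino, or hydrogen in place of hydroxy, changes the result at all.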